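Swapping an octyl for a phenyl on a weak cytotoxic core

The source may report more compounds than this note shows. Statements on the series, on what has been measured and on what is new or still open speak of the compounds shown alone.

Of the compounds shown here, three built on one shared core have been tested in a functional assay on ACHN cells (Homo sapiens) for cytotoxicity, read by sulforhodamine B assay, with a stated time of 72 h; on this read-out lower numbers stand for stronger inhibition of growth and higher numbers for weaker inhibition of growth. Compound 1 `CCCCCCCCC(=O)N1c2ccccc2CCC1C(=O)Nc1ccccc1C(F)(F)F` gives 8330 nM in this assay. Compound 2 `O=C(Nc1ccccc1C(F)(F)F)C1CCc2ccccc2N1C(=O)c1ccccc1` gives 8090 nM in this assay. Compound 3 `CCCCCCCCC(=O)N1c2ccccc2CCC1C(=O)Nc1ccccc1O` gives 65000 nM in this assay, the highest of the three numbers.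

Two single changes connect them. From compound 1 to compound 2 the change is phenyl in place of octyl on a carbonyl carbon, and the step it made was a 1.0-fold lower number from compound 1 to compound 2 (0.01 log units; within the scatter). From compound 1 to compound 3 the change is hydroxy in place of trifluoromethyl on an aromatic carbon, and the step was a 7.8-fold higher number from compound 1 to compound 3 (0.89 log units; beyond the scatter); this is also how the core of compound 3 differs from the core of compound 1.

Compound 4 `O=C(Nc1ccccc1O)C1CCc2ccccc2N1C(=O)c1ccccc1` has not yet been measured in this assay. For the measured compounds named here, it differs from compound 3 by phenyl in place of octyl on a carbonyl carbon, which is the same change, at the same place, as the one from compound 1 to compound 2. Since that earlier step, a 1.0-fold lower number from compound 1 to compound 2 (0.01 log units; within the scatter), stayed within the scatter, compound 4 is expected to land close to compound 3, with an estimated step of no change at the digits printed from compound 3 to compound 4 (within the scatter). Going by the values given here, the estimate for compound 4 is therefore 65000 nM, with a range from 25000 nM to 170000 nM, resting on only one prior example of this change.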

Compound 4, concentration for 50% growth inhibition: 4260 nM
Beside the measured number, compound 4's estimate is 15-fold (1.18 log units) above it, and the stated range ends above it.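

In this assay, phenyl in place of octyl on the carbonyl carbon gives a 15-fold lower number from compound 3 to compound 4 (1.18 log units; beyond the scatter), so a change that did nothing measurable on the core of compound 1 has a large effect on the core of compound 3: the same change on two cores in this assay, a 1.0-fold lower number (0.01 log units; within the scatter) from compound 1 to compound 2 and a 15-fold lower number (1.18 log units; beyond the scatter) from compound 3 to compound 4, 15-fold (1.17 log units) apart, beyond the scatter of two such steps

Read the other way round, hydroxy in place of trifluoromethyl costs activity when octylcarbonyl is present, yet with benzoyl it gives a 1.9-fold lower number from compound 2 to compound 4 (0.28 log units; within the scatter), a step that stays within the scatter: the same change on two cores in this assay, a 7.8-fold higher number (0.89 log units; beyond the scatter) from compound 1 to compound 3 and a 1.9-fold lower number (0.28 log units; within the scatter) from compound 2 to compound 4, 15-fold (1.17 log units) apart, beyond the scatter of two such steps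

Together these four compounds show that the size of each change depends on what sits at the other place, so a step measured on one core cannot simply be transferred to another in this series, but a single set of four compounds in one cell line does not show why the two places are linked or whether the link extends to other groups.

From the compounds shown here alone, it remains open whether a shorter chain such as butyl, or a substituted benzoyl, would behave like octyl or like phenyl on the hydroxy core. Going by these compounds, it is also open whether an amine or a carboxylic acid in place of the hydroxy would keep the growth inhibition seen with compound 4.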